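Two thiazoles measured, a third awaits its value

The source may hold more compounds than are shown below. What is called first, only, known or untested is meant among the compounds shown, and "the series" means these compounds.

Compound 1 `CNC(=N)Nc1nc(-c2ccc(OC)cc2)c(-c2ccc(OC)cc2)s1`: 1.2 uM
Compound 2 `COc1ccc(-c2nc(CNC(=O)NC(C)C)sc2-c2ccc(OC)cc2)cc1`: 5.7 uM

In a functional assay (aorta) with Rattus norvegicus as the target (a higher number here means that more compound is needed for the effect, a lower number that less compound is needed), compound 1 gives the lowest of the two numbers; compound 2 gives a 4.8-fold higher number from compound 1 to compound 2 (0.68 log units; beyond the scatter). Compound 3 `CCN(CC)C(=O)c1nc(-c2ccc(OC)cc2)c(-c2ccc(OC)cc2)s1` differs from compound 1 as follows: a group of 7 heavy atoms (5 carbon, 1 nitrogen, 1 oxygen; no ring) in place of a group of 5 heavy atoms (2 carbon, 3 nitrogen; no ring), on an aromatic carbon. Going by the values given here, the only step that bears on this change is the one from compound 1 to compound 2, which also exchanged the same group on that aromatic carbon and was modest in size. A weakening of comparable size is therefore expected for compound 3, as a 5.0-fold higher number from compound 1 to compound 3 (0.70 log units; beyond the scatter). Compound 3 is estimated at 6 uM in this assay, with a range from 2 uM to 20 uM.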

Compound 3, concentration for half-maximal effect: 14 uM
The estimate for compound 3 lay 2.3-fold (0.37 log units) below the measured number, and the stated range covers the measured number.
By their numbers in this assay, from the lowest: compound 1; then compound 2; then compound 3.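

In this assay, a second replacement of the group on this aromatic carbon again raises the number, with a 12-fold higher number from compound 1 to compound 3 (1.07 log units; beyond the scatter), so diethylcarbamoyl costs more than the earlier step had shown. The two replacements also differ from each other, with a 2.5-fold higher number from compound 2 to compound 3 (0.39 log units; beyond the scatter), and compound 1 remains the lowest of the three. Nothing available here explains these differences. The compounds shown leave open how a primary amine or a carboxylic acid on this aromatic carbon would compare with compound 1.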